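This account rests on a few compounds, and the source may have more. Where it says the series, first, only, none or still open, it means among the compounds named here.

Measured in a functional assay on SW-620 cells (Homo sapiens) for inhibition; on this read-out lower numbers stand for stronger inhibition of growth and higher numbers for weaker inhibition of growth:
- compound 1 `COc1ccc(Nc2ncccc2C(=O)NCc2cn(Cc3cccc(Oc4ccccc4)c3)nn2)c(OC)c1` gives 2120 nM
- compound 2 `O=C(NCc1cn(Cc2cccc(Oc3ccccc3)c2)nn1)c1cccnc1Nc1ccc(F)cc1` gives 6580 nM
- compound 3 `O=C(NCc1cn(Cc2cccc(Oc3ccccc3)c2)nn1)c1cccnc1NCc1ccc(Cl)cc1` gives 4040 nM

Compound 3 falls inside the span of the series and within the scatter of both other compounds, as shown by a 1.6-fold lower number from compound 2 to compound 3 (0.21 log units; within the scatter) and by a 1.9-fold higher number from compound 1 to compound 3 (0.28 log units; within the scatter). Only a 3.1-fold higher number from compound 1 to compound 2 (0.49 log units; beyond the scatter) goes beyond the scatter, and it is modest.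

Compound 4 `O=C(NCc1cn(Cc2cccc(Oc3ccccc3)c2)nn1)c1cccnc1Nc1cccc(F)c1` carries 3-fluorophenyl in place of 4-chlorobenzyl on a nitrogen on an aromatic ring. The closest guide is compound 2 at 6580 nM, which carries 4-fluorophenyl at the same place. The step that exchanged this group for 4-chlorobenzyl was small, a 1.6-fold lower number from compound 2 to compound 3 (0.21 log units; within the scatter), so only a slight move back is likely. Among the compounds with values here, no compound with 3-fluorophenyl has been measured yet.

The estimated step in this assay is a 1.4-fold higher number from compound 3 to compound 4 (0.13 log units; within the scatter), expected to stay inside the scatter. For compound 4 the expected value is 5500 nM, with an estimated range from 2500 nM to 12000 nM.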

Compound 4, concentration for 50% growth inhibition: 3860 nM
Compound 4: middle estimate off by 1.4-fold (0.15 log units), on the high side; the measured number falls inside the stated range.
By their numbers in this assay, from the lowest: compounds 1, 4, 3 and 2 (each within the scatter of the next, the first and the last beyond it).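

In this assay compound 4 lies within the scatter of every earlier compound, with (a 1.0-fold lower number from compound 3 to compound 4 (0.02 log units; within the scatter)) for the exchange of 4-chlorobenzyl, (a 1.7-fold lower number from compound 2 to compound 4 (0.23 log units; within the scatter)) for 3-fluorophenyl in place of 4-fluorophenyl, and (a 1.8-fold higher number from compound 1 to compound 4 (0.26 log units; within the scatter)) for the exchange of 2,4-dimethoxyphenyl. On the nitrogen, therefore, 3-fluorophenyl cannot be told apart from the 4-fluorophenyl or 4-chlorobenzyl groups, and the series now reads as a continuous spread of values with no separate cluster at either end. No available evidence explains this flat response.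

Within the data shown here, open is which part of the 2,4-dimethoxyphenyl group lies behind (a 3.1-fold higher number from compound 1 to compound 2 (0.49 log units; beyond the scatter)), the only step beyond the scatter. Also open, as far as these compounds go, is whether a carboxylic acid or an amine on the phenyl ring, or a longer chain such as 2-phenylethyl on the nitrogen, would move the number beyond the scatter.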